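This account rests on a few compounds, and the source may have more. Where it says the series, first, only, none or still open, it means among the compounds named here.

Compound 1 `CCc1nc(-c2ccc(OC)cc2)c(C(=O)N2CCN(c3cccc(Cl)c3)CC2)o1` and compound 2 `CCc1nc(-c2ccc(OC)c(OC)c2)c(C(=O)N2CCN(c3cccc(Cl)c3)CC2)o1` share the same core and differ only in the methoxy substitution of the aryl group. In a functional assay on HL-60 cells (Homo sapiens) for inhibition, read by MTT assay, with a stated time of 72 h (on this read-out higher numbers stand for weaker inhibition and lower numbers for stronger inhibition), compound 1 gives only a limit, > 1000 nM, which is the limit of > 1000 nM in this assay, at which 1 of the 2 values shown sits. Compound 2 is reported in this assay as "not active" (no number reported), so no number stands for it at all. Compound 3 `CCCc1nc(-c2ccc(OC)c(OC)c2)c(C(=O)N2CCN(c3cccc(Cl)c3)CC2)o1` is set apart from compound 2 by methyl in place of hydrogen on a saturated chain carbon, two bonds along the chain from an aromatic carbon. For the measured compounds named here, no measured step of this kind is available, and no change beyond the scatter is expected in this assay. Compound 3 is therefore expected to give about 5000 nM, within 1500 nM to 30000 nM.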

Compound 3, half-maximal inhibitory concentration: "not active" (no number reported)
Compound 3: no number reported; the estimate stays without a comparison.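

Compound 3, like compound 2, is reported as not active in this assay without a number, so no step can be read between them. The compounds shown leave open whether methyl in place of hydrogen changes inhibition at all.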